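The source may report more compounds than this note shows. Statements on the series, on what has been measured and on what is new or still open speak of the compounds shown alone.

Compound 1 `COc1ccc(-c2cnc(NC(=O)c3ccno3)n2C)cc1`: in a toxicity assay on THP-1 cells (Homo sapiens) for inhibition (a lower number here means that less compound is tolerated, a higher number that more compound is tolerated), compound 1 gives > 100000 nM, which is a limit of the assay and not a number. Compound 2 `Cn1c(-c2cccc([N+](=O)[O-])c2)cnc1NC(=O)c1ccc(F)cc1`: in this assay compound 2 gives > 50000 nM, again a limit rather than a number. Compound 3 `Cn1c(-c2ccc(Cl)cc2)cnc1NC(=O)c1ncc[nH]1`: in this assay compound 3 gives 52000 nM.

Compound 1 thus stands at the limit of > 100000 nM in this assay, at which 1 of the 3 values shown sits, the upper edge of what was measured, and only compound 3 has a number; compound 2 sits at the limit of > 50000 nM in this assay, at which 1 of the 3 values shown sits. For the measured compounds named here, no step between measured compounds that differ in one place is available, so the measured data say nothing about the size of a single change. Compound 4 `COc1ccc(-c2cnc(NC(=O)c3ccn[nH]3)n2C)cc1` differs from compound 1 in one place: 1H-pyrazol-5-yl in place of 1,2-oxazol-5-yl on a carbonyl carbon. The account expects the step that the limit leaves unreadable from compound 1 to compound 4 to be none beyond the scatter. Compound 4 is therefore estimated at 120000 nM, with a range of 50000 nM to 300000 nM, most likely reported again as a limit.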

Compound 4, half-maximal cytotoxic concentration: > 100000 nM
Compound 4: no number, only a limit; the forecaster's own chance of this, stated with the estimate: 70%; the middle value does not contradict the limit.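

Compound 1 and compound 4 both give only a limit in this assay, so the step between them cannot be read. The compounds shown leave open whether 1H-pyrazol-5-yl and 1,2-oxazol-5-yl on a carbonyl carbon differ at all in cytotoxic concentration.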